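From phenyl to 2-hydroxyphenyl on the shared core

The source may hold more compounds than are shown below. What is called first, only, known or untested is meant among the compounds shown, and "the series" means these compounds.

Compound 1 `CC1(C)[C@H]2CC[C@]1(C)N(Cc1cn(-c3cccc(F)c3)nn1)C(=O)C2` gives 430 nM
Compound 2 `CC1(C)[C@H]2CC[C@]1(C)N(Cc1cn(-c3ccccc3)nn1)C(=O)C2` gives 50 nM

In a functional assay on OVCAR-3 cells (Homo sapiens) for inhibition, read by MTT assay, with a stated time of 24 h (on this read-out higher numbers stand for weaker inhibition and lower numbers for stronger inhibition), compound 2 has the lower of the two numbers, so it is the stronger inhibitor so far. Compound 3 `CC1(C)[C@H]2CC[C@]1(C)N(Cc1cn(-c3ccccc3O)nn1)C(=O)C2` carries hydroxy in place of hydrogen on an aromatic carbon, ortho to a large group: hydroxy in place of hydrogen on an aromatic carbon. Going by the values given here, one measured step bears on this, an 8.6-fold lower number from compound 1 to compound 2 (0.93 log units; beyond the scatter) with hydrogen in place of fluoro. Read in reverse, adding a group raised the number, but fluoro is not hydroxy, so this is only a rough guide. The expected change is a 2.8-fold higher number from compound 2 to compound 3 (0.45 log units; beyond the scatter) in this assay as a moderate rise. Compound 3 is therefore estimated at 140 nM within a range of 35 nM to 550 nM as the likely span.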

Compound 3, half-maximal inhibitory concentration: 90 nM
Compound 3: middle estimate off by 1.6-fold (0.19 log units), on the high side; low and high end bracket the measured number.
By their numbers in this assay, from the lowest: compounds 2 and 3 (each within the scatter of the next); then compound 1.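

With hydroxy on the aromatic carbon ortho to a large group, this assay shows a 1.8-fold higher number from compound 2 to compound 3 (0.26 log units; within the scatter), so a group at this place need not carry a clear cost. Swapping 3-fluorophenyl for 2-hydroxyphenyl gives a 4.8-fold lower number from compound 1 to compound 3 (0.68 log units; beyond the scatter), which shows that not every substituted phenyl behaves like compound 1. Nothing available explains this result.

Fluoro and hydroxy also sit at different places on the ring, so the effect of the group cannot be separated from that of its place. Going by these compounds, whether an amine or methoxy on the same carbon would match hydroxy remains open.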